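Trimethoxyphenyl Pyrazole Enones: Dropping One Methoxy Group

The source may hold more compounds than are shown below. What is called first, only, known or untested is meant among the compounds shown, and "the series" means these compounds.

Of the compounds shown here, three of a shared core have been measured in a functional assay on NCI-H23 cells (Homo sapiens) for cytotoxicity, read by sulforhodamine B assay, with a stated time of 48 h, tested at 0.01 uM; a higher number here means a weaker effect of the compound at the concentration tested, a lower number a stronger effect. Compound 1 `COc1ccc(-c2cc(/C=C/C(=O)c3ccc(N)cc3)[nH]n2)cc1` gives 92%. Compound 2 `COc1ccc(-c2cc(/C=C/C(=O)c3ccc(N)cc3)[nH]n2)cc1OC` gives 103% in this assay. Compound 3 `COc1cc(C(=O)/C=C/c2cc(-c3cc(OC)c(OC)c(OC)c3)n[nH]2)cc(OC)c1OC` gives 100% in this assay; the difference between the core of compound 3 and that of compound 2 is not broken down here. Between compound 2 and compound 1 the change is hydrogen in place of methoxy on an aromatic carbon, and it gave a step of a number 11 percentage points lower from compound 2 to compound 1 (beyond the scatter).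

Compound 4 `COc1ccc(-c2cc(/C=C/C(=O)c3cc(OC)c(OC)c(OC)c3)[nH]n2)cc1OC` has not yet been measured. It differs from compound 3 by hydrogen in place of methoxy on an aromatic carbon. This is the same kind of change as that from compound 2 to compound 1, though not the same: in compound 3 the carbon that loses its methoxy is also meta to a methoxy group (2 heavy atoms), which is not said of the place in compound 2. For the measured compounds named here, the earlier step of a number 11 percentage points lower from compound 2 to compound 1 (beyond the scatter) is the only guide available. For compound 4 a step of similar size is expected, a number 10 percentage points lower from compound 3 to compound 4 (within the scatter). Compound 4 is therefore estimated at 90% in this assay, expected to fall between 78% and 104%.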

Compound 4, a percentage reported as activity, at one concentration (the size of the read-out at that concentration, not a potency): 94%
The estimate for compound 4 lay 4 percentage points below the measured number; the measured number falls inside the stated range.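

In this assay, hydrogen in place of methoxy on an aromatic carbon gave a number 6 percentage points lower from compound 3 to compound 4 (within the scatter). Set beside the earlier step, this one does not differ from it, so as far as these two pairs go, the change carried over from one core to the other without a detectable difference in size: the same change on two cores in this assay, a number 11 percentage points lower (beyond the scatter) from compound 2 to compound 1 and a number 6 percentage points lower (within the scatter) from compound 3 to compound 4, 5 percentage points apart, within the scatter of two such steps. For the compounds shown here, this does not show that the change has a fixed size across the series: only two pairs are at hand, just one of the two steps lies beyond the scatter, and a reading at a single concentration is not a potency.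

The compounds shown carry only methoxy or hydrogen at this aromatic carbon, so what a hydroxyl group, a fluorine atom or an ethoxy group would do there remains open. Also open, from the compounds shown here alone, is whether the same change would give a step of similar size at higher concentrations, where the read-out might lie further from the top of its range.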